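Chloro to methoxy on the pendant aryl across two cores

This account rests on a few compounds, and the source may have more. Where it says the series, first, only, none or still open, it means among the compounds named here.

Compound 1 `Nc1cccc(-c2cn3nc(Cc4ccc(Cl)cc4)sc3n2)c1` and compound 2 `COc1ccc(Cc2nn3cc(-c4cccc(N)c4)nc3s2)cc1` share one core; compound 3 `C=C(Br)C(=O)Nc1cccc(-c2cn3c(-c4ccc(Cl)cc4)csc3n2)c1` and compound 4 `C=C(Br)C(=O)Nc1cccc(-c2cn3c(-c4ccc(OC)cc4)csc3n2)c1` share another. The difference between the two cores is not broken down here. In a functional assay on CCRF-CEM cells (Homo sapiens) for inhibition, read by cell counting, with a stated time of 3 days (a lower number here means a stronger inhibitor, a higher number a weaker inhibitor), compound 1 gives 42000 nM. Compound 2 reaches only a limit of the assay, >= 250000 nM. The change methoxy in place of chloro on an aromatic carbon thus produces an at least 5.9-fold higher number from compound 1 to compound 2 (0.77 log units; beyond the scatter), with the value resting on (the limit of >= 250000 nM in this assay, at which 1 of the 3 values shown sits). Compound 3 gives 2200 nM in this assay. Compound 4 differs from compound 3 by methoxy in place of chloro on an aromatic carbon, the same change at the same place. The earlier pair gave an at least 5.9-fold higher number from compound 1 to compound 2 (0.77 log units; beyond the scatter), so a weakening of at least that size is expected here. The expected step is a 6.8-fold higher number from compound 3 to compound 4 (0.83 log units; beyond the scatter). Compound 4 is therefore estimated at 15000 nM. For compound 4 the expected range is 5000 nM to 60000 nM.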

Compound 4, half-maximal inhibitory concentration: 500 nM
The estimate for compound 4 lay 30-fold (1.48 log units) above the measured number, outside the stated range (below it).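

On the core of compound 3, methoxy in place of chloro gives a 4.4-fold lower number from compound 3 to compound 4 (0.64 log units; beyond the scatter) in this assay, the opposite direction to the earlier pair. The change therefore does not carry over between these two cores with a common sign or size: the same change on two cores in this assay, an at least 5.9-fold higher number (0.77 log units; beyond the scatter) from compound 1 to compound 2 and a 4.4-fold lower number (0.64 log units; beyond the scatter) from compound 3 to compound 4, at least 26-fold (1.41 log units) apart, beyond the scatter of two such steps The earlier step rests on an assay limit, so its direction can be read but its size cannot, and two pairs do not show which structural difference reverses the step: the limit of >= 250000 nM in this assay, at which 1 of the 4 values shown sits.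

Still open, from the compounds shown here alone, is whether the reversal follows the core or the amine-to-bromoacrylamide difference between the pairs. Also open, going by these compounds, is how fluoro or hydroxy in the same place would behave on either core.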